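The source may hold more compounds than are shown below. What is called first, only, known or untested is meant among the compounds shown, and "the series" means these compounds.

Of the compounds shown here, three sharing one core have been tested in a functional assay on T47D cells (Homo sapiens) for cytotoxicity, read by sulforhodamine B assay; on this read-out lower numbers stand for stronger inhibition and higher numbers for weaker inhibition. Compound 1 `[N-]=[N+]=N[C@@H]1C(n2ccc(=O)[nH]c2=O)[Se][C@H](CO)[C@H]1O` carries an azido group on a saturated ring carbon. In this assay compound 1 gives > 100000 nM, which is a limit of the assay and not a number. Compound 2 `Cc1cn(C2[Se][C@H](CO)[C@@H](O)[C@@H]2N=[N+]=[N-])c(=O)[nH]c1=O` has a methyl in place of hydrogen on an aromatic carbon. In this assay compound 2 gives > 100000 nM, again a limit. Compound 3 `O=c1ccn(C2[Se][C@H](CO)[C@@H](O)[C@@H]2O)c(=O)[nH]1` has a hydroxy in place of azido on a saturated ring carbon. In this assay compound 3 gives > 100000 nM, once more a limit.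

Compound 3 therefore stands only at a limit, and the two other values are limits as well. The step that the two limits leave unreadable from compound 1 to compound 2 and the step that the two limits leave unreadable from compound 1 to compound 3 cannot be read, because of the limit of > 100000 nM in this assay, at which 3 of the 3 values shown sit.

Compound 4 `Cc1cn(C2[Se][C@H](CO)[C@@H](O)[C@@H]2O)c(=O)[nH]c1=O` differs from compound 3 by methyl in place of hydrogen on an aromatic carbon. The same change was measured from compound 1 to compound 2, where it could not be read between two limits. With all three values at the limit, compound 4 is expected to stay there too. The expected step is a step that the limit leaves unreadable from compound 3 to compound 4, none beyond the scatter. Compound 4 is thus estimated at 150000 nM, within a range from 50000 nM to 500000 nM.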

Compound 4, half-maximal inhibitory concentration: > 100000 nM
Compound 4: only a limit was reported (the forecaster's own chance of this, stated with the estimate: 90%); the middle value is on the limit's open side.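

The steps from compound 3 and from compound 2 to compound 4 cannot be read, because compound 4 also gives only a limit: the limit of > 100000 nM in this assay, at which 4 of the 4 values shown sit.

The compounds shown leave open whether methyl in place of hydrogen, or hydroxy in place of azido, changes the result at all in this assay.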